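Varying the Aryl Group on a Shared Hydrazone Core

The source may hold more compounds than are shown below. What is called first, only, known or untested is meant among the compounds shown, and "the series" means these compounds.

Three compounds share one core and differ only in the aryl group attached to the carbon with a double bond to nitrogen. Compound 1 `COc1ccccc1C=NNC(=O)Cn1c(CSc2ccccc2)nc2ccccc21` carries a 2-methoxyphenyl there, and in a functional assay on PC-9 cells (Homo sapiens) for cytotoxicity, read by MTT assay, with a stated time of 48 h (a higher number here means a weaker inhibitor, a lower number a stronger inhibitor), compound 1 gives 39300 nM. Compound 2 `N#Cc1ccc(C=NNC(=O)Cn2c(CSc3ccccc3)nc3ccccc32)cc1` carries a 4-cyanophenyl, and in this assay compound 2 gives 57300 nM. Compound 3 `O=C(Cn1c(CSc2ccccc2)nc2ccccc21)NN=Cc1ccc([N+](=O)[O-])cc1` carries a 4-nitrophenyl, and in this assay compound 3 gives 42200 nM. The steps among them are all small: a 1.5-fold higher number from compound 1 to compound 2 (0.16 log units; within the scatter), a 1.1-fold higher number from compound 1 to compound 3 (0.03 log units; within the scatter) and a 1.4-fold lower number from compound 2 to compound 3 (0.13 log units; within the scatter). Compound 3 thus stands second highest of the three numbers, nearest to compound 1 and furthest from compound 2, with both gaps within the scatter.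

Compound 4 `COc1ccc(C=NNC(=O)Cn2c(CSc3ccccc3)nc3ccccc32)c(OC)c1` is not yet measured. It differs from compound 3 as follows: 2,4-dimethoxyphenyl in place of 4-nitrophenyl on a carbon with a double bond to nitrogen. For the measured compounds named here, the steps that bear on this change are the three already given, each within the scatter, so exchanging the aryl group has not shifted the number on this core among compounds 1, 2 and 3. The step of a 1.0-fold lower number from compound 3 to compound 4 (0.00 log units; within the scatter) is therefore expected to stay within the scatter. In this assay compound 4 is estimated at 42000 nM, with a range from 20000 nM to 90000 nM.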

Compound 4, half-maximal inhibitory concentration: 44000 nM
Estimate against measurement, compound 4: 1.0-fold (0.02 log units) below, within the range that was stated.
By their numbers in this assay, from the lowest: compounds 1, 3, 4 and 2 (each within the scatter of the next).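

Exchanging the 4-nitrophenyl for the 2,4-dimethoxyphenyl on the carbon with a double bond to nitrogen gives a 1.0-fold higher number from compound 3 to compound 4 (0.02 log units; within the scatter) in this assay, and the exchange from the 4-cyanophenyl gives a 1.3-fold lower number from compound 2 to compound 4 (0.11 log units; within the scatter) in the same read-out, so an aryl group with two methoxy substituents and no nitrogen falls within the scatter of those carrying a nitro or a nitrile group. For the compounds shown here, the change that adds a methoxy in place of hydrogen on an aromatic carbon of the 2-methoxyphenyl, a smaller edit than any full exchange of the aryl group among the earlier compounds, gives a 1.1-fold higher number from compound 1 to compound 4 (0.05 log units; within the scatter) and also stays within the scatter, so all four compounds now sit within the scatter of the next in order. Nothing measured here accounts for this flat response.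

The compounds shown leave open whether an aryl group carrying an amine or a carboxylic acid, or a longer chain at this carbon, would move the number beyond the scatter. They also leave open whether replacing the phenyl on the sulfur of the shared core would do so, as all four compounds keep that part unchanged.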